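The source may report more compounds than this note shows. Statements on the series, on what has been measured and on what is new or still open speak of the compounds shown alone.

Measured so far:
compound 1 `Cc1cc(C(=O)O)nn1Cc1cc(Br)ccc1OCc1ccccc1` gives 1.2 in a physicochemical assay for lipophilicity, at pH 7.4; a lower number here means a more polar compound, a higher number a more lipophilic compound.
In this assay compound 2 `Cc1cc(C(=O)Nc2ccccn2)nn1Cc1cc(Cl)ccc1OCc1ccccc1` gives > 3.7, which is a limit of the assay and not a number.

Compound 2 therefore stands at the upper edge of what this assay reports, where one of the two values sits (the limit of > 3.7 in this assay, at which 1 of the 2 values shown sits). Compound 3 `Cc1cc(NC(=O)c2ccccc2)nn1Cc1cc(Cl)ccc1OCc1ccccc1` differs from compound 2 by benzamido in place of (pyridin-2-yl)carbamoyl on an aromatic carbon. Going by the values given here, no step between measured compounds is known. The step that the limit leaves unreadable from compound 2 to compound 3 is expected to be small and upward, beyond the scatter only marginally. Compound 3 is expected to give 4.2, within 3.7 to 4.8, most likely again reported as a limit.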

Compound 3, distribution coefficient: > 3.7
Compound 3: a limit, no number; the forecaster's own chance of this, stated with the estimate: 75%; the middle value is on the limit's open side.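

In this assay compound 3 gives > 3.7, which is a limit of the assay and not a number. Going by these compounds alone, no step from compound 2 to compound 3 can be read, since both values are limits: the limit of > 3.7 in this assay, at which 2 of the 3 values shown sit. On these data alone, how far apart these two compounds lie, and in which direction, remains open.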